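The compounds below may be only part of what the source reports. "The series", "measured", "known", "first", "only" and "open" are said of these compounds alone.

Of the compounds shown here, two of one series have been tested in an assay on isolated protein for inhibition of Maltase-glucoamylase (Homo sapiens), with a stated time of 15 min; on this read-out higher numbers stand for weaker inhibition and lower numbers for stronger inhibition. Compound 1, `COc1ccc(/C=N/NC(=O)c2ccc(-c3nc4ccccc4s3)cc2)c(O)c1`, carries a hydroxy group beside its methoxy-bearing ring, and in this assay compound 1 gives 6970 nM, a weak inhibition. Compound 2, `COc1ccc(/C=N/NC(=O)c2ccc(-c3nc4ccccc4s3)cc2)cc1OC`, carries two methoxy groups instead, and in this assay compound 2 is reported as "not active" (no number reported), so no number stands for it at all; where compound 2 stands on the scale of numbers is therefore unknown, apart from the fact that it did not register as an inhibitor.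

The step to compound 3, `COc1ccc(/C=N/NC(=O)c2ccc(-c3nc4ccccc4s3)cc2)cc1O`, is small: hydrogen in place of methyl on an oxygen on an aromatic ring. The 3,4-dimethoxyphenyl of compound 2 becomes a 3-hydroxy-4-methoxyphenyl. Among the compounds with values here, no measured pair shows what such a change does in this assay, so the size of the step cannot be read from the data; a change from no activity to a measurable but weak inhibition, near where compound 1 stands, seems the most likely outcome, though a further report of no activity would not surprise. Compound 3 is expected to give about 9000 nM in this assay, within a range of 3000 nM to 30000 nM.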

Compound 3, half-maximal inhibitory concentration: "not active" (no number reported)
Nothing numeric was reported for compound 3, so the estimate cannot be set against anything.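

Within the data shown here, compound 2 and compound 3 are both reported as not active in this assay and carry no number, so no step between them can be read. No measurement shown here offers an explanation for this result. The compounds shown leave open what changing methoxy to hydroxy does to inhibition on this read-out.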